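From benzyloxy to phenoxy: a step among limits

The source may report more compounds than this note shows. Statements on the series, on what has been measured and on what is new or still open speak of the compounds shown alone.

Compound 1 `CCOC(=O)c1c(-c2cccc(OCC)c2)[nH]c2cc(OC)ccc2c1=O`: > 21500 nM
Compound 2 `CCCOc1cccc(-c2[nH]c3cc(OC)ccc3c(=O)c2C(=O)OCC)c1`: > 21500 nM
Compound 3 `CCOC(=O)c1c(-c2cccc(OCc3ccccc3)c2)[nH]c2cc(OC)ccc2c1=O`: > 21500 nM

In an ADME assay on BJ cells (Homo sapiens) for cytotoxicity, read by luminescence, with a stated time of 72 h (on this read-out lower numbers stand for an effect already at smaller amounts and higher numbers for an effect only at larger amounts of compound), compound 3 gives > 21500 nM, which is a limit of the assay and not a number. The values of compounds 1 and 2 are limits too, so compound 3 cannot be ranked against either of them.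

Compound 4 `CCOC(=O)c1c(-c2cccc(Oc3ccccc3)c2)[nH]c2cc(OC)ccc2c1=O` has not yet been measured. It differs from compound 3 by a single change, phenyl in place of benzyl on an oxygen on an aromatic ring. Cut one bond further out, the same difference reads benzyloxy to phenoxy.

Three measured steps also change the group on that oxygen: a step that the two limits leave unreadable from compound 1 to compound 2, a step that the two limits leave unreadable from compound 1 to compound 3 and a step that the two limits leave unreadable from compound 2 to compound 3. None of them has a readable size, so they offer no measured effect to carry over. Across compounds 1, 2 and 3, changing this group has not yet produced a number.

The expectation in this assay is therefore no step beyond the scatter, in either direction, and most likely another limit, because of the limit of > 21500 nM in this assay, at which 3 of the 3 values shown sit. The expected step is a step that the limit leaves unreadable from compound 3 to compound 4. For compound 4 the estimate is 25000 nM, with an expected range from 12000 nM to 60000 nM.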

Compound 4, half-maximal effective concentration: > 21500 nM
Compound 4 gave a limit, no number; the forecaster's own chance of this, stated with the estimate: 85%; the middle value is on the limit's open side.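

In this assay compound 4 gives > 21500 nM, which is a limit of the assay and not a number. For the compounds shown here, no step from compound 1, compound 2 or compound 3 to compound 4 can be read, because all of them end in limits: the limit of > 21500 nM in this assay, at which 4 of the 4 values shown sit. The compounds shown leave open whether the ethyl, propyl, benzyl and phenyl groups on that oxygen differ at all in this assay.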